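A few compounds are considered here, and "the series" means these few. Any claim that something is new, unique, unknown or untested is made for them only; others in the source may bear on it.

Compound 1 `CCCCNC(=O)C1C(C(=O)O)[C@@H]2CC[C@H]1O2`: 10000 nM
Compound 2 `O=C(O)C1C(C(=O)NCC2Cc3ccsc3CO2)[C@H]2CC[C@@H]1O2`: 10000 nM
Compound 3 `Cn1ccc2cc(CNC(=O)C3C(C(=O)O)[C@@H]4CC[C@H]3O4)ccc21`: 10000 nM

These three compounds share a core and were tested in an ADME assay on DU-145 cells (Homo sapiens) for cytotoxicity, read by MTT assay, with a stated time of 72 h; on this read-out lower numbers stand for stronger inhibition of growth and higher numbers for weaker inhibition of growth. Compound 1 gives 10000 nM in this assay, and compounds 2 and 3 stand level with it at the digits shown. The gaps from compound 1 to compound 2 and to compound 3 both lie within the scatter, so none of the three can be called stronger or weaker than another, and the three values together describe a flat picture. Within the data shown here, no pair of measured compounds differs in a single place, so no step between measured compounds can be drawn on.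

Compound 4 `O=C(O)CCCNC(=O)C1C(C(=O)O)[C@@H]2CC[C@H]1O2` has not yet been measured in this assay. It differs from compound 1 by carboxy in place of methyl on a saturated chain carbon, three bonds along the chain from an amide-type nitrogen. Among the measured compounds shown here, with three measured compounds all at one level and no single-place step to lean on, the step from compound 1 to compound 4 is expected to be none beyond the scatter, no change at the digits printed from compound 1 to compound 4 (within the scatter). Compound 4 is therefore estimated to give about 10000 nM, with a range from 5000 nM to 20000 nM.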

Compound 4, concentration for 50% growth inhibition: 10000 nM
The estimate for compound 4 equals the measured number at the digits printed; the range from low to high includes it.
By their numbers in this assay, from the lowest: compounds 1, 2, 3 and 4 (each within the scatter of the next).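

The step from butyl to 3-carboxypropyl is the only single-place comparison among these compounds, and in this assay it gives no change at the digits printed from compound 1 to compound 4 (within the scatter). At this place, on a saturated chain carbon three bonds along the chain from an amide-type nitrogen, carboxy in place of methyl brings one more hydrogen-bond donor and one more hydrogen-bond acceptor, yet the value stays level with those of compounds 2 and 3. Nothing measured here offers an explanation for this result.

From the compounds shown here alone, whether an amine, a phenyl ring or a longer chain at this place would leave that shared level remains open. With only one single-place step available, the compounds shown also leave open whether any change to the shared core would register in this assay at all.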